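The source may hold more compounds than are shown below. What is called first, only, known or untested is meant among the compounds shown, and "the series" means these compounds.

Compound 1 `O=C(CCc1cccc(C(F)(F)F)c1)Nc1cc(Oc2ccc3nc(NC(=O)C4CC4)sc3c2)ccc1F` gives 650 nM in a functional assay on HT-29 cells (Homo sapiens) for inhibition, read by luminescence and CellTiter-Glo, with a stated time of 12 h; a higher number here means that more compound is needed for the effect, a lower number that less compound is needed. Compound 2 `Cc1cccc(NC(=O)Nc2cc(Oc3ccc4nc(NC(=O)C5CC5)sc4c3)ccc2F)c1` carries a (3-methylphenyl)amino in place of the 2-(3-(trifluoromethyl)phenyl)ethyl of compound 1 on the carbonyl carbon. In this assay compound 2 gives 580 nM, so that a 1.1-fold lower number from compound 1 to compound 2 (0.05 log units; within the scatter). Among the compounds with values here, compound 3 `CCOC(=O)c1cccc(NC(=O)Nc2cc(Oc3ccc4nc(NC(=O)C5CC5)sc4c3)ccc2F)c1` gives 7740 nM in this assay and stands with the highest number of the three compounds measured so far: a 12-fold higher number from compound 1 to compound 3 (1.08 log units; beyond the scatter), and a 13-fold higher number from compound 2 to compound 3 (1.13 log units; beyond the scatter). Compound 4 `O=C(Nc1cccc(Br)c1)Nc1cc(Oc2ccc3nc(NC(=O)C4CC4)sc3c2)ccc1F` has not yet been measured. It differs from compound 3 by bromo in place of ethoxycarbonyl on an aromatic carbon. Within the data shown here, only one of the measured steps bears directly on this change, namely a 13-fold higher number from compound 2 to compound 3 (1.13 log units; beyond the scatter), in which a methyl on the same aromatic carbon was exchanged for the ethoxycarbonyl that compound 4 now loses. Since compound 4 replaces that ethoxycarbonyl with bromo, a single-atom group, a large step downward in this assay is expected, roughly undoing the earlier rise, and the estimate is an 11-fold lower number from compound 3 to compound 4 (1.04 log units; beyond the scatter). Compound 4 is therefore expected to give about 700 nM in this assay, with a likely range from 300 nM to 2000 nM.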

Compound 4, half-maximal effective concentration: 440 nM
The estimate for compound 4 lay 1.6-fold (0.20 log units) above the measured number; the range from low to high includes it.
By their numbers in this assay, from the lowest: compounds 4, 2 and 1 (each within the scatter of the next); then compound 3.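

Within the data shown here, on this aromatic carbon of the six-membered ring, meta to a large group, the earlier compounds had compared ethoxycarbonyl only with methyl; bromo in place of ethoxycarbonyl now gives an 18-fold lower number from compound 3 to compound 4 (1.25 log units; beyond the scatter) in this assay, so a second group, with a single heavy atom and no hydrogen-bond acceptors, also stands far from the ester. Bromo and methyl cannot be told apart here, with a 1.3-fold lower number from compound 2 to compound 4 (0.12 log units; within the scatter), so among the three groups seen on this carbon, ethoxycarbonyl alone stands apart. Among these compounds, the (3-bromophenyl)amino on the carbonyl carbon also stays level with the 2-(3-(trifluoromethyl)phenyl)ethyl, with a 1.5-fold lower number from compound 1 to compound 4 (0.17 log units; within the scatter), which means that compound 3 is the only one of the four compounds whose number lies beyond the scatter of the others.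

The compounds shown leave open how a carboxylic acid, a primary amide or an amine would fare on this carbon, and whether methoxycarbonyl would stand with ethoxycarbonyl or with bromo. Nothing measured here accounts for the distance of ethoxycarbonyl from methyl and bromo.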